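Replacing the Isobutyl Group on the Ring Amide Nitrogen

The source may report more compounds than this note shows. Statements on the series, on what has been measured and on what is new or still open speak of the compounds shown alone.

Three compounds share one core. Compound 1 `Cc1cnc(CN2CC(=O)N(CC(C)C)c3c(Cl)nc(N)nc32)c(C)c1Br`, compound 2 `COc1c(C)cnc(CN2CC(=O)N(CC(C)C)c3c(Cl)nc(N)nc32)c1C` and compound 3 `COc1c(C)cnc(CN2c3nc(N)nc(Cl)c3NC(=O)[C@@H]2C)c1C` were all tested in a functional assay on BT-474 cells (Homo sapiens) for inhibition; on this read-out lower numbers stand for stronger inhibition and higher numbers for weaker inhibition. In this assay compound 1 gives 130 nM. Compound 2 gives 20 nM, and compound 3 gives 470 nM. Among the compounds with values here, the only single-point step among them is a 6.5-fold lower number from compound 1 to compound 2 (0.81 log units; beyond the scatter). Compound 2 therefore stands with the lowest number of the three, clearly separated from the other two.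

Compound 4 `COc1c(C)cnc(CN2CC(=O)N(C(C)C(=O)NCCN(C)C)c3c(Cl)nc(N)nc32)c1C` has not yet been measured. It differs from compound 2 in one place: 1-((2-(dimethylamino)ethyl)carbamoyl)ethyl in place of isobutyl on an amide-type nitrogen in a ring. Within the data shown here, no measured step touches this amide-type nitrogen in a ring; the one step known, a 6.5-fold lower number from compound 1 to compound 2 (0.81 log units; beyond the scatter), concerns an aromatic carbon elsewhere, and compound 3 differs from compound 2 in more than one place, so its value shows only that such multiple changes weakened inhibition. With no direct guide, a modest weakening is expected, a 3.0-fold higher number from compound 2 to compound 4 (0.48 log units; beyond the scatter). Compound 4 is estimated at 60 nM, within a range from 15 nM to 300 nM.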

Compound 4, half-maximal inhibitory concentration: 60 nM
Estimate against measurement, compound 4: no gap at the digits printed; measured number inside the range.
By their numbers in this assay, from the lowest: compound 2; then compound 4; then compound 1; then compound 3.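

Within the data shown here, this is the first measured change on the amide-type nitrogen in a ring: in this assay, 1-((2-(dimethylamino)ethyl)carbamoyl)ethyl in place of isobutyl gives a 3.0-fold higher number from compound 2 to compound 4 (0.48 log units; beyond the scatter) and the step is modest. In this one pair, a chain of 10 heavy atoms replaces one of 4 heavy atoms and brings a hydrogen-bond donor and hydrogen-bond acceptors that isobutyl lacks, yet inhibition is weakened rather than lost. The position therefore tolerates a far larger group with only a limited change in the number.

Still open, from the compounds shown here alone, is how a chain carrying a carboxylic acid in place of the dimethylamino group, or a simple methyl on this nitrogen, would read in this assay. Nothing measured here gives a cause for the step.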